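Methoxy to ethoxy on the aryl ring of compound 1

The source may report more compounds than this note shows. Statements on the series, on what has been measured and on what is new or still open speak of the compounds shown alone.

Compound 1, `COC(=O)N1N=C(c2cccc(OC)c2)CC1c1cc(OC)c(OC)c(OC)c1`: 1300 nM
Compound 2, `CCCOC(=O)N1N=C(c2cccc(OC)c2)CC1c1cc(OC)c(OC)c(OC)c1`: > 10000 nM

Of the compounds shown here, two with a shared core have been measured in a functional assay on HT-29 cells (Homo sapiens) for antiproliferative activity, read by MTT assay, with a stated time of 48 h; a higher number here means a weaker inhibitor of growth, a lower number a stronger inhibitor of growth. For the measured compounds named here, compound 1 gives 1300 nM, the only number reported. For compound 2 the result is a limit of the assay, (the limit of > 10000 nM in this assay, at which 1 of the 2 values shown sits). Going by the values given here, the one measured step, an at least 7.6-fold higher number from compound 1 to compound 2 (0.88 log units; beyond the scatter), corresponds to ethyl in place of hydrogen on a saturated chain carbon bound to an oxygen next to a carbonyl group.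

Compound 3, `CCOc1cccc(C2=NN(C(=O)OC)C(c3cc(OC)c(OC)c(OC)c3)C2)c1`, has not yet been measured. It differs from compound 1 by methyl in place of hydrogen on a saturated chain carbon bound to an oxygen on an aromatic ring. Among the compounds with values here, this change sits at a different place from the one measured step, which concerns the chain on the oxygen next to the carbonyl group rather than the methoxy on the aromatic ring, so that step gives only indirect guidance. A step of modest size is expected, with its direction uncertain, and a reported limit cannot be ruled out. The estimated step is a 1.7-fold higher number from compound 1 to compound 3 (0.23 log units; within the scatter). Compound 3 is therefore expected to give about 2200 nM, within a range from 600 nM to 8000 nM.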

Compound 3, concentration for 50% growth inhibition: 4450 nM
Compound 3: middle estimate off by 2.0-fold (0.31 log units), on the low side, within the range that was stated.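

For the compounds shown here, until this result, only the chain on the oxygen next to a carbonyl group had been varied; the methoxy on the aromatic ring had not, and in this assay methoxy to ethoxy there gives a 3.4-fold higher number from compound 1 to compound 3 (0.53 log units; beyond the scatter). The 3-methoxyphenyl position therefore responds to a single added methyl, and the change weakens growth inhibition without removing it, since compound 3 still gives a measurable number. Compound 2, changed at the other place, gives a limit of the assay and not a number, so the true size of its step stays unknown and the two changes cannot be ranked against each other: the limit of > 10000 nM in this assay, at which 1 of the 3 values shown sits.

What the compounds shown leave open is whether a longer chain such as propoxy on this oxygen would weaken growth inhibition further, or whether a hydroxyl or an amine in place of the methoxy would reverse the direction of the change. One step also says nothing about why the added methyl matters, or about whether the same change would act alike on the other methoxy groups of compound 1.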